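This account rests on a few compounds, and the source may have more. Where it says the series, first, only, none or still open, it means among the compounds named here.

Working notes on the series, cytotoxicity read in an ADME assay on RAW264.7 cells (Mus musculus) for cytotoxicity, read by MTT assay, with a stated time of 72 h, tested at 50 ug/mL; on this read-out lower numbers stand for less inhibition and higher numbers for more inhibition at the one concentration tested (going by the name of the read-out).

Compound 1 `CC(=O)c1ccc(N2CCN(C(=O)c3nc4cc(Cl)ccc4s3)CC2)cc1` gives 30.8% in this assay. Compound 2 `CN1CCN(C(=O)c2nc3ccccc3s2)CC1` gives 52.1%, and compound 3 `CN1CCN(C(=O)c2nc3cc(C(F)(F)F)ccc3s2)CC1` gives 12.6%. On these three numbers compound 1 stands second highest: compound 3 lies below it beyond the scatter, compound 2 lies above it beyond the scatter.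

For the measured compounds named here, the only single-place step measured so far is a number 39.5 percentage points lower from compound 2 to compound 3 (beyond the scatter). That change sits on the aromatic part of the shared core, not on the group carried by the ring nitrogen, so it does not bear directly on the step considered here.

Compound 4 `COc1ccccc1N1CCN(C(=O)c2nc3cc(Cl)ccc3s2)CC1` differs from compound 1 in one place, (2-methoxyphenyl in place of 4-acetylphenyl on an amine nitrogen in a ring). Compound 1 differs from compound 2 and from compound 3 in more than one place, so for those pairs only the two values can be set side by side; they show compound 1 between the other two. Going by the values given here, no measured step changes the group on the amine nitrogen in a ring, and nothing points to a direction for this exchange. Compound 4 is therefore expected to stay close to compound 1, with a number 0.8 percentage points lower from compound 1 to compound 4 (within the scatter) estimated to lie within the scatter. The expected value for compound 4 is 30%, in a range from 10% to 50%.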

Compound 4, a percentage reported as inhibition, at one concentration (the size of the read-out at that concentration, not a potency): 63.4%
Beside the measured number, compound 4's estimate is 33.4 percentage points below it; measured number outside the range, above it.
By their numbers in this assay, from the lowest: compound 3; then compound 1; then compound 2; then compound 4.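

In this assay, the group on the amine nitrogen in a ring clearly matters: with 2-methoxyphenyl in place of 4-acetylphenyl, the step is a number 32.6 percentage points higher from compound 1 to compound 4 (beyond the scatter). For the compounds shown here, this is the first step measured at this position, and it shows that exchanging one substituted aromatic group for another can produce a large change, even though the computed counts of hydrogen-bond donors and acceptors do not differ between the two groups and neither group carries a net charge. No measured information on the compounds accounts for this step.

The step changes the substituent and its place on the aromatic ring together, so the compounds shown cannot separate the methoxy-for-acetyl exchange from the change of place, and a single step on the core of compound 1 does not show whether the same change would hold on another core. Also open, as far as these compounds go, is how an unsubstituted phenyl, or a short chain ending in an amine or a carboxylic acid, would read on the same ring nitrogen.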